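Swapping a hexyl amide for a piperazine amide

This account rests on a few compounds, and the source may have more. Where it says the series, first, only, none or still open, it means among the compounds named here.

In a functional assay on the whole organism (strain Wistar) for inhibition, with Rattus norvegicus as the target, read by paw edema, with stated times of 60 min and 1 h, at a dose of 100 mg/kg by the oral route (on this read-out higher numbers stand for more inhibition at the one dose given (going by the name of the read-out) and lower numbers for less inhibition), compound 1 `COc1cc2c(cc1OC)C(CC(=O)O)CC2` gives 18.8%. Turning its acid into an amide raises the number: compound 2 `CCCCNC(=O)CC1CCc2cc(OC)c(OC)cc21` gives 31.3%, a change of a number 12.5 percentage points higher from compound 1 to compound 2 (beyond the scatter), and compound 3 `CCCCCCNC(=O)CC1CCc2cc(OC)c(OC)cc21` gives 47.6%, a change of a number 28.8 percentage points higher from compound 1 to compound 3 (beyond the scatter). Lengthening the chain accounts for a number 16.3 percentage points higher from compound 2 to compound 3 (beyond the scatter). Compound 3 therefore stands highest of the three measured compounds, beyond the scatter from both others.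

Compound 4 `COc1cc2c(cc1OC)C(CC(=O)N1CCNCC1)CC2` differs from compound 3 by piperazin-1-yl in place of hexylamino on a carbonyl carbon. Within the data shown here, no measured step swaps one amide substituent for another of this kind; both amide steps from compound 1 raised inhibition modestly, and the only comparison among amides is a chain extension. The shorter amide of compound 2 gave 31.3% while the longer one of compound 3 gave 47.6%. With a ring now in place of the chain, compound 4 is expected to fall back toward the shorter amide, an estimated step of a number 12.6 percentage points lower from compound 3 to compound 4 (beyond the scatter). Compound 4 is thus estimated at 35%, within 15% to 55%.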

Compound 4, a percentage reported as inhibition, in the whole organism at one dose (the size of the read-out at that dose, not a potency): 62.5%
For compound 4 the middle estimate is 27.5 percentage points below the measured one, and the stated range ends below it.
By their numbers in this assay, from the lowest: compound 1; then compound 2; then compound 3; then compound 4.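

In this assay the carbonyl carbon carries a ring as well as a chain: piperazin-1-yl in place of hexylamino gives a number 14.9 percentage points higher from compound 3 to compound 4 (beyond the scatter) and so shows that a long straight chain is not needed for the highest number among these compounds. The same ring gives a number 31.2 percentage points higher from compound 2 to compound 4 (beyond the scatter) and a number 43.7 percentage points higher from compound 1 to compound 4 (beyond the scatter) as its larger steps, and these place compound 4 highest of the four, beyond the scatter from each of the others. Nothing at hand explains why the ring outdoes the chain.

Still open, going by these compounds, is whether the second ring nitrogen matters, which a piperidine amide, with carbon in its place, or a morpholine amide, with oxygen there, could show. Also open, on these data alone, is how a methyl group on that nitrogen would change the number.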